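A Saturated Branch on the Aromatic Nitrogen

The source may hold more compounds than are shown below. What is called first, only, known or untested is meant among the compounds shown, and "the series" means these compounds.

Three compounds sharing one core and differing only in the group on the aromatic nitrogen have been measured in an assay on Prostate gland for inhibition of steroid 5-alpha-reductase (Rattus norvegicus); on this read-out lower numbers stand for stronger inhibition and higher numbers for weaker inhibition. Compound 1 `CCCn1ccc2cc(/C(C)=C/C(=O)Nc3ccccc3OCCCC(=O)O)ccc21` gives 190 nM, compound 2 `C/C(=C\C(=O)Nc1ccccc1OCCCC(=O)O)c1ccc2c(ccn2CC(C)C)c1` gives 160 nM, and compound 3 `CC(C)=CCn1ccc2cc(/C(C)=C/C(=O)Nc3ccccc3OCCCC(=O)O)ccc21` gives 120 nM, the lowest of the three numbers shown, though its gaps to compound 2 and to compound 1 both lie within the scatter. The step of a 1.2-fold lower number from compound 1 to compound 2 (0.07 log units; within the scatter) stayed within the scatter, as did a 1.6-fold lower number from compound 1 to compound 3 (0.20 log units; within the scatter) and a 1.3-fold lower number from compound 2 to compound 3 (0.12 log units; within the scatter). Compound 4 `CCC(C)n1ccc2cc(/C(C)=C/C(=O)Nc3ccccc3OCCCC(=O)O)ccc21` differs from compound 3 by sec-butyl in place of 3-methylbut-2-en-1-yl on an aromatic nitrogen. All three measured steps bear on this change, each having exchanged one group on the aromatic nitrogen for another without moving the number beyond the scatter. The account therefore expects no step beyond the scatter in this assay, the estimated change being a 1.3-fold higher number from compound 3 to compound 4 (0.10 log units; within the scatter). For compound 4 the estimated value in this assay is 150 nM, expected to fall between 70 nM and 320 nM.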

Compound 4, half-maximal inhibitory concentration: 67 nM
Estimate against measurement, compound 4: 2.2-fold (0.35 log units) above; measured number outside the range, below it.
By their numbers in this assay, from the lowest: compounds 4, 3, 2 and 1 (each within the scatter of the next, the first and the last beyond it).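

In this assay, going by these compounds alone, a methyl on the saturated chain carbon bound to the aromatic nitrogen is the first change here to pass the scatter: the data show a 2.8-fold lower number from compound 1 to compound 4 (0.45 log units; beyond the scatter) and, with sec-butyl in place of isobutyl, a 2.4-fold lower number from compound 2 to compound 4 (0.38 log units; beyond the scatter) as well, whereas the methyl placed further along the chain gave only a 1.2-fold lower number from compound 1 to compound 2 (0.07 log units; within the scatter) and stayed within it. Sec-butyl is still not separated from 3-methylbut-2-en-1-yl, as a 1.8-fold lower number from compound 3 to compound 4 (0.25 log units; within the scatter) lies within the scatter. No measurement available here gives a reason for these steps.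

The compounds shown leave open whether isopropyl or cyclopentyl on the aromatic nitrogen would give a number like that of compound 4. They also leave open whether a hydroxyl or an amine on the sec-butyl chain would keep it.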